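Formyl to Hydroxymethyl on a Shared Core

The source may report more compounds than this note shows. Statements on the series, on what has been measured and on what is new or still open speak of the compounds shown alone.

Measured compounds:
- Compound 1, `COc1ccc(/C=C\c2cc(OC)c(OC)c(OC)c2)cc1OCc1ccc(CN2CC(C(=O)O)C2)cc1`: in a functional assay on MC-38 cells (Mus musculus) for antiproliferative activity, read by CCK-8 assay, with a stated time of 48 h (a lower number here means a stronger inhibitor, a higher number a weaker inhibitor), compound 1 gives > 10000 nM, a limit of the assay.
- Compound 2, `COc1ccc(/C=C\c2cc(OC)c(OC)c(OC)c2)cc1OCc1ccc(CN2C[C@H](O)C[C@@H]2C(=O)O)cc1`: compound 2 gives > 10000 nM, also a limit.
- Compound 3, `COc1ccc(/C=C\c2cc(OC)c(OC)c(OC)c2)cc1OCc1ccc(C=O)cc1`: compound 3 gives 900 nM.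

For the measured compounds named here, compound 3 thus holds the only number among the three; the other two sit at the limit of > 10000 nM in this assay, at which 2 of the 3 values shown sit. The steps of an at least 11-fold lower number from compound 1 to compound 3 (1.04 log units; beyond the scatter) and an at least 11-fold lower number from compound 2 to compound 3 (1.04 log units; beyond the scatter) are large, but both swap a carboxy-bearing amine group for formyl and say nothing about changing the formyl itself. Compound 4, `COc1ccc(/C=C\c2cc(OC)c(OC)c(OC)c2)cc1OCc1ccc(CO)cc1`, differs from compound 3 by hydroxymethyl in place of formyl on an aromatic carbon. Going by the values given here, no measured step covers this change, so any expectation rests on the structures alone. The expected step of a 1.7-fold higher number from compound 3 to compound 4 (0.22 log units; within the scatter) is small, near the scatter, with compound 4 estimated at 1500 nM, between 500 nM and 5000 nM.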

Compound 4, half-maximal inhibitory concentration: 5700 nM
The estimate for compound 4 lay 3.8-fold (0.58 log units) below the measured number, outside the stated range (above it).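

In this assay, the formyl group itself matters: a 6.3-fold higher number from compound 3 to compound 4 (0.80 log units; beyond the scatter) is a step beyond the scatter, although hydroxymethyl only swaps formyl for a group that adds a hydrogen-bond donor. Earlier steps replaced the whole carboxy-bearing amine group, so they could not show this. Against those amines the readings are only floors, an at least 1.7-fold lower number from compound 2 to compound 4 (0.24 log units; that floor lies within the scatter) and an at least 1.7-fold lower number from compound 1 to compound 4 (0.24 log units; that floor lies within the scatter), so compound 4 cannot be firmly ranked against them.

Why formyl gives the lower number stays open. So does how a carboxylic acid or a primary amine in place of formyl would compare.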